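The source may hold more compounds than are shown below. What is called first, only, known or untested is meant among the compounds shown, and "the series" means these compounds.

In a functional assay on cells (Platelet, Homo sapiens) for inhibition (a lower number here means a stronger inhibitor, a higher number a weaker inhibitor), compound 1 `CCOC(=O)c1cccc(-c2n[nH]c3ccccc23)c1` gives > 10000 nM, which is a limit of the assay and not a number. Compound 2 `CCOC(=O)c1ccc(-c2nn(Cc3cccc(F)c3)c3ccccc23)cc1` gives > 10000 nM, which is also a limit. Together these form (the limit of > 10000 nM in this assay, at which 2 of the 2 values shown sit), so no measured step is available as a guide. Compound 3 `CCOC(=O)c1cccc(-c2nn(Cc3ccccc3)c3ccccc23)c1` is compound 1 with benzyl in place of hydrogen on an aromatic nitrogen. Compound 2 also carries a group on an aromatic nitrogen and still gives > 10000 nM, so a large gain in this assay is not expected. A modest move toward stronger inhibition is the expectation, and the estimated change is an at least 1.2-fold lower number from compound 1 to compound 3 (0.09 log units; that floor lies within the scatter). The result could also prove to be only a limit again. For compound 3 the expected value is 8000 nM, with an estimated range of 1500 nM to 20000 nM.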

Compound 3, half-maximal inhibitory concentration: > 10000 nM
Compound 3 ended at the assay's limit; the forecaster's own chance of this, stated with the estimate: 60%; at least 1.2-fold (0.09 log units) between middle value and limit.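

Compound 1 and compound 3 both give a limit and not a number, so the step from hydrogen to benzyl on the aromatic nitrogen cannot be read: the limit of > 10000 nM in this assay, at which 3 of the 3 values shown sit. The compounds shown leave open which change, if any, would bring a measurable value in this assay.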